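One Stereocentre Changed in a Very Low-Dose Compound

The source may hold more compounds than are shown below. What is called first, only, known or untested is meant among the compounds shown, and "the series" means these compounds.

Among the compounds with values here, compound 2 (`FC(F)(F)CCCSc1nsnc1[C@H]1CN2CCC[C@H]1C2`) stands lowest of the two numbers so far in a functional assay on the whole organism with Mustela putorius furo as the target (on this read-out higher numbers stand for an effect only at larger amounts of compound and lower numbers for an effect already at smaller amounts), where compound 2 gives 0.00017 mg/kg and compound 1 (`FC(F)(F)CCCSc1nsnc1[C@H]1CN2CCC[C@@H]1C2`) gives 0.0053 mg/kg. Between them lies the single measured step, a 31-fold lower number from compound 1 to compound 2 (1.49 log units; beyond the scatter), which is large and beyond the scatter although the atoms and bonds stay the same. Only a stereocentre at a saturated ring carbon differs there, drawn S in compound 1 and R in compound 2.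

Compound 3 (`FC(F)(F)CCCSc1nsnc1[C@@H]1CN2CCC[C@H]1C2`) is related to compound 2 by a change of the same kind: the two compounds have the same atoms and bonds; at least one stereo element is drawn with a configuration in one of them and without one in the other: 1 of 3 stereo elements differ; a stereocentre at a saturated ring carbon is drawn R in compound 2 and S in compound 3. Here a stereocentre at a saturated ring carbon is drawn R in compound 2 and S in compound 3.

Within the data shown here, the step of a 31-fold lower number from compound 1 to compound 2 (1.49 log units; beyond the scatter) is the only guide, and it shows that one such change can matter greatly in this assay. Since compound 2 already sits lowest at 0.00017 mg/kg, a move towards a higher number is expected. The expected change is a 24-fold higher number from compound 2 to compound 3 (1.37 log units; beyond the scatter) and it should be large. For compound 3 the estimate is 0.004 mg/kg with an expected range from 0.0006 mg/kg to 0.03 mg/kg on this single precedent.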

Compound 3, dose for half-maximal effect: 0.0047 mg/kg
Estimate against measurement, compound 3: 1.2-fold (0.07 log units) below, and the stated range covers the measured number.
By their numbers in this assay, from the lowest: compound 2; then compounds 3 and 1 (each within the scatter of the next).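

In this assay, the result shows that the stereocentre changed here also matters greatly: this ring carbon is a different one from the one changed before, and it gives a 28-fold higher number from compound 2 to compound 3 (1.44 log units; beyond the scatter), which is large, as is a 31-fold lower number from compound 1 to compound 2 (1.49 log units; beyond the scatter). Compounds 1 and 3 differ at both of these stereocentres, yet the step between them is a 1.1-fold lower number from compound 1 to compound 3 (0.05 log units; within the scatter), so changing both leaves no difference that can be read, and compound 2 alone stands apart among the three. Since the atoms and bonds stay the same, the gap between compounds 2 and 3 can rest only on how the stereocentre is drawn: the fact that one of compounds 2 and 3 is drawn with a defined configuration and the other without, at the place where they differ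

The three compounds leave open how this stereochemical preference arises and whether it extends to other arrangements of the shared core. They also leave open whether a gap of this size would survive if the trifluoromethyl at the end of the chain gave way to a nitrile, or if the chain itself were replaced by a longer chain.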